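A few compounds are considered here, and "the series" means these few. Any claim that something is new, unique, unknown or untested is made for them only; others in the source may bear on it.

Measured so far:
compound 1, `CC/C(=C(/c1ccc(NC(=O)C(C)C)cc1)c1ccc(OC)cc1)c1ccccc1`, giving > 30000 nM in a functional assay on HeLa cells (Homo sapiens) for inhibition, read by trypan blue exclusion, with a stated time of 72 h (a lower number here means a stronger inhibitor of growth, a higher number a weaker inhibitor of growth), which is a limit of the assay and not a number;
compound 2, `CC/C(=C(/c1ccc(NC(=O)C(C)C)cc1)c1ccc(OC)cc1)c1ccc(Cl)cc1Cl`, giving 2200 nM in this assay;
compound 3, `CC/C(=C(/c1ccccc1)c1ccc(NC(=O)C(C)C)cc1)c1ccccc1`, giving 28100 nM in this assay.

Compound 1 and compound 2 share a core and differ in one place: 2,4-dichlorophenyl in place of phenyl on a double-bonded chain carbon bound to a double-bonded chain carbon and a saturated chain carbon. This change brings an at least 13-fold lower number from compound 1 to compound 2 (1.13 log units; beyond the scatter). Compound 3 carries a different core, and the difference between the two cores is not broken down here; compound 3 stands with the highest measured number, and compound 2 sits at a much lower number.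

Compound 4, `CC/C(=C(/c1ccccc1)c1ccc(NC(=O)C(C)C)cc1)c1ccc(Cl)cc1Cl`, is not yet measured. It stands to compound 3 as compound 2 stands to compound 1: 2,4-dichlorophenyl in place of phenyl on a double-bonded chain carbon bound to a double-bonded chain carbon and a saturated chain carbon. The place is worded the same for both pairs, so this is the same change made on a second core.

For compound 4 a step of about an 11-fold lower number from compound 3 to compound 4 (1.05 log units; beyond the scatter) is expected, because the same change gave an at least 13-fold lower number from compound 1 to compound 2 (1.13 log units; beyond the scatter), a step that can only be read as a lower bound since compound 1 sits at a limit (the limit of > 30000 nM in this assay, at which 1 of the 3 values shown sits). On that basis compound 4 is estimated at 2500 nM, within 700 nM to 9000 nM.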

Compound 4, concentration for 50% growth inhibition: 8200 nM
Compound 4: the middle estimate sits 3.3-fold (0.52 log units) below what was measured; the measured number falls inside the stated range.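

On the second core, 2,4-dichlorophenyl in place of phenyl gives a 3.4-fold lower number from compound 3 to compound 4 (0.53 log units; beyond the scatter), so in this assay the direction of the change carries over from one core to the other. The size of the step does not carry over, and the two steps differ by more than repeated measurements would explain: the same change on two cores in this assay, an at least 13-fold lower number (1.13 log units; beyond the scatter) from compound 1 to compound 2 and a 3.4-fold lower number (0.53 log units; beyond the scatter) from compound 3 to compound 4, at least 3.9-fold (0.59 log units) apart, beyond the scatter of two such steps. Compound 1 gives > 30000 nM, which is a limit and not a number, so the gap between the two steps is known only as a lower bound.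

The compounds shown leave open whether both chlorine atoms are needed for the lower number, or whether a phenyl ring with a single chlorine, or with methyl or methoxy groups in their place, would serve as well. They also leave open what in the two cores sets the size of the step, and whether the direction would hold on a third core, such as one carrying an amine or a carboxylic acid.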